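Swapping trifluoromethyl for chloro on compound 3

The compounds below may be only part of what the source reports. "The series", "measured", "known", "first", "only" and "open" are said of these compounds alone.

Measured so far in a functional assay on CCRF-CEM cells (Homo sapiens) for inhibition, read by MTT assay, with a stated time of 72 h; a lower number here means a stronger inhibitor, a higher number a weaker inhibitor:
- Compound 1 `COc1cc(NC(C)CCCNC(=O)Nc2cccc(F)c2)c2ncccc2c1`: 21000 nM
- Compound 2 `COc1cc(NC(C)CCCNC(=O)Nc2cccc(C(F)(F)F)c2)c2ncccc2c1`: 19000 nM
- Compound 3 `COc1cc(NC(C)CCCNC(=O)NNC(=O)Nc2cccc(C(F)(F)F)c2)c2ncccc2c1`: 6900 nM

Of these three, compound 3 has the lowest number at 6900 nM, which makes it the strongest inhibitor of the set. The numbers of compound 1 and compound 2 both lie above it by more than the usual scatter of repeated measurements.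

The next compound to be tested is compound 4 `COc1cc(NC(C)CCCNC(=O)NNC(=O)Nc2cccc(Cl)c2)c2ncccc2c1`. It keeps the whole of compound 3 except for one small group: chloro in place of trifluoromethyl on an aromatic carbon. Put simply, chloro takes the place of trifluoromethyl on an aromatic carbon.

For the measured compounds named here, only one measured step bears on this kind of swap, a 1.1-fold lower number from compound 1 to compound 2 (0.04 log units; within the scatter). It exchanged fluoro for trifluoromethyl and barely moved the number. Going by the values given here, that step comes from a different chain than the one in compound 3, and no chloro compound has been measured yet, so the evidence is thin.

On that basis, no change beyond the scatter is expected in this assay. The expected step is small, a 1.0-fold higher number from compound 3 to compound 4 (0.01 log units; within the scatter). For compound 4 the estimated value is 7000 nM, with an expected range from 3500 nM to 14000 nM.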

Compound 4, half-maximal inhibitory concentration: 81000 nM
Beside the measured number, compound 4's estimate is 12-fold (1.06 log units) below it, and the stated range ends below it.
By their numbers in this assay, from the lowest: compound 3; then compounds 2 and 1 (each within the scatter of the next); then compound 4.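

In this assay, for the compounds shown here, the group on the aromatic carbon proves far from neutral on the chain of compound 3, where chloro in place of trifluoromethyl gives a large loss (a 12-fold higher number from compound 3 to compound 4 (1.07 log units; beyond the scatter)), although the only earlier swap at this place, fluoro to trifluoromethyl on a different chain, stayed within the scatter. The longer chain therefore does not bring a lower number on its own: compound 3 has the lowest number of the set, yet compound 4, which has the same chain, sits above both compounds with the shorter chain (a 4.3-fold higher number from compound 2 to compound 4 (0.63 log units; beyond the scatter); a 3.9-fold higher number from compound 1 to compound 4 (0.59 log units; beyond the scatter)), so the benefit of that chain holds only with trifluoromethyl on the ring among these compounds. No measurement here accounts for the difference between chloro and trifluoromethyl.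

Going by these compounds, it remains open how chloro would behave on the chain of compound 2, which would show whether the large step belongs to the longer chain alone. On these data alone, it is also open where a methyl, a methoxy or a nitrile at this same place on the chain of compound 3 would fall relative to compound 3 and compound 4.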